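The source may report more compounds than this note shows. Statements on the series, on what has been measured and on what is new or still open speak of the compounds shown alone.

Measured compounds:
Compound 1, `COc1ccc(-c2nc3c(c(C)nn3-c3ccccc3)c(-c3ccccc3O)c2C#N)cc1`, in an ADME assay on BJ cells (Homo sapiens) for cytotoxicity, with a stated time of 72 h (a higher number here means that more compound is needed for the effect, a lower number that less compound is needed), gives > 23000 nM, a limit of the assay.
Compound 2, `CCc1ccc(-c2nc3c(c(C)nn3-c3ccccc3)c(-c3ccccc3S(C)(=O)=O)c2C#N)cc1`, in this assay gives > 20000 nM, a limit of the assay.
Compound 3, `CCc1ccc(-c2nc3c(c(C)nn3-c3ccccc3)c(-c3ccccc3)c2C#N)cc1`, in this assay gives > 20000 nM, a limit of the assay.

Compound 1 therefore stands at the limit of > 23000 nM in this assay, at which 1 of the 3 values shown sits, while its two companions sit at the limit of > 20000 nM in this assay, at which 2 of the 3 values shown sit. Among the compounds with values here, none of the three values is a number, so no compound can be set above or below another. Within the data shown here, the one step between compounds that differ in a single place, a step that the two limits leave unreadable from compound 2 to compound 3, shows that the two limits leave it unreadable.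

Compound 4, `Cc1nn(-c2ccccc2)c2nc(-c3ccc(C(F)(F)F)cc3)c(C#N)c(-c3ccccc3O)c12`, is not yet measured. It differs from compound 1 by trifluoromethyl in place of methoxy on an aromatic carbon. Among the measured compounds shown here, no measured step matches this change, and the only recorded step is unreadable, so nothing points to a direction beyond the scatter. Compound 4 is expected to stay at the limit as well, with an estimate of 25000 nM, ranging from 8000 nM to 80000 nM. The step that this estimate means, a step that the limit leaves unreadable from compound 1 to compound 4, is expected to lie within the scatter.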

Compound 4, half-maximal effective concentration: 22900 nM
Estimate against measurement, compound 4: 1.1-fold (0.04 log units) above, and the stated range covers the measured number.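

Within the data shown here, with trifluoromethyl in place of methoxy on an aromatic carbon of a six-membered aromatic ring of carbon only, para to a large group, compound 4 gives 22900 nM in this assay, the only value shown that is a number and not a limit. The change therefore reads as a number no higher from compound 1 to compound 4 (the limit leaves the size open). The size of this step cannot be read because compound 1 stands at a limit of the assay: the limit of > 23000 nM in this assay, at which 1 of the 4 values shown sits.

The compounds shown leave open whether an amine or a carboxylic acid at this same place would also give a number in this assay. They also leave open whether trifluoromethyl in place of the ethyl of compound 3 would give a number there.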